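This account rests on a few compounds, and the source may have more. Where it says the series, first, only, none or still open, it means among the compounds named here.

Measured so far in a functional assay on MCF7 cells (Homo sapiens) for antiproliferative activity, read by sulforhodamine B assay, with a stated time of 72 h; on this read-out higher numbers stand for weaker inhibition and lower numbers for stronger inhibition
- compound 1 `COc1c(OC(C)C)cc2occ(-c3csc4ccccc34)c(=O)c2c1OC(C)C` with > 10000 nM as a limit
- compound 2 `O=C(/C=C/c1csc2ccccc12)c1cc(Br)ccc1O` with 1040 nM
- compound 3 `Cc1ccc(O)c(C(=O)/C=C/c2csc3ccccc23)c1` with 7800 nM

The value of compound 1 is a limit of the assay and not a number. Compound 3 stands highest of the two numbers, at 7800 nM in this assay and with compound 2 as its nearest neighbour. The change to compound 4 `CCOc1ccc(O)c(C(=O)/C=C/c2csc3ccccc23)c1` is ethoxy in place of methyl on an aromatic carbon para to a hydroxy group. Within the data shown here, one measured step bears on this place: a 7.5-fold higher number from compound 2 to compound 3 (0.88 log units; beyond the scatter) for methyl in place of bromo, modest but beyond the scatter. Among the measured compounds shown here, with only that step as a guide, a modest change toward a lower number is expected. The expected change is a 2.2-fold lower number from compound 3 to compound 4 (0.35 log units; beyond the scatter) as an estimate of modest size. For compound 4 the estimated value is 3500 nM with an expected range of 1000 nM to 12000 nM as the likely span.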

Compound 4, half-maximal inhibitory concentration: 7500 nM
Estimate against measurement, compound 4: 2.1-fold (0.33 log units) below; measured number inside the range.
By their numbers in this assay, from the lowest: compound 2; then compounds 4 and 3 (each within the scatter of the next). At a limit, above all of these: compound 1.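

On the position para to a hydroxy group, ethoxy in place of methyl gives no readable difference in this assay (a 1.0-fold lower number from compound 3 to compound 4 (0.02 log units; within the scatter)), although the entering group is larger and carries an oxygen. Bromo is still set apart from ethoxy as it was from methyl (a 7.2-fold higher number from compound 2 to compound 4 (0.86 log units; beyond the scatter)), so of the three groups at this place only bromo stands out. The compounds shown offer no measured basis for giving a cause for either step.

As far as these compounds go, whether an amine, a carboxylic acid or a longer chain here would stay with methyl and ethoxy or come closer to bromo remains open. So does whether another halogen such as chloro would match bromo.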